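Cyano in place of trifluoromethyl: compound 3 to compound 4

The source may hold more compounds than are shown below. What is called first, only, known or untested is meant among the compounds shown, and "the series" means these compounds.

In an ADME assay on Jurkat cells (Homo sapiens) for cytotoxicity, read by trypan blue exclusion, with a stated time of 24 h (on this read-out higher numbers stand for weaker inhibition and lower numbers for stronger inhibition), compound 1 `N#C[Se]c1ccc(N)cc1` gives 43800 nM and compound 2 `N#C[Se]Cc1ccccc1[N+](=O)[O-]` gives 12900 nM while compound 3 `N#C[Se]Cc1ccc(C(F)(F)F)cc1` gives 7310 nM on the same read-out. Compound 3 thus lies within the scatter of compound 2 and beyond the scatter of compound 1, with the smaller number of that pair. Compound 4 `N#C[Se]Cc1ccc(C#N)cc1` carries cyano in place of trifluoromethyl on an aromatic carbon and still awaits measurement. Within the data shown here, no measured pair differs in one place, so the expectation rests on compound 3 at 7310 nM and compound 2 at 12900 nM, and no step beyond the scatter is expected in this assay in either direction. The expected change is a 1.4-fold higher number from compound 3 to compound 4 (0.14 log units; within the scatter) and stays within the scatter. The estimated value for compound 4 is 10000 nM with an expected range from 4500 nM to 20000 nM in repeated measurements.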

Compound 4, half-maximal inhibitory concentration: 13400 nM
Compound 4: middle estimate off by 1.3-fold (0.13 log units), on the low side; the measured number falls inside the stated range.
By their numbers in this assay, from the lowest: compounds 3, 2 and 4 (each within the scatter of the next); then compound 1.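

In this assay, the first pair differing in one place shows cyano in place of trifluoromethyl on an aromatic carbon giving a 1.8-fold higher number from compound 3 to compound 4 (0.26 log units; within the scatter) on this read-out. At this position, the exchange therefore does not separate the two compounds, although cyano brings a hydrogen-bond acceptor and fewer heavy atoms than trifluoromethyl. No supporting measurement explains this result.

From the compounds shown here alone, what remains open is how an amine, a carboxylic acid or a methoxy group would read at the same position. Going by these compounds, whether a longer chain there would give a step beyond the scatter also remains open.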